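Notes on a cytotoxicity series, compounds 1 to 4

This account rests on a few compounds, and the source may have more. Where it says the series, first, only, none or still open, it means among the compounds named here.

Measured so far:
- compound 1 `Cc1ccc(C(=O)N2N=C(c3cc4ccccc4oc3=O)CC2c2ccccc2)cc1`: in a functional assay on PC-3 cells (Homo sapiens) for cytotoxicity, read by MTT assay, with a stated time of 48 h (a higher number here means a weaker inhibitor, a lower number a stronger inhibitor), compound 1 gives 13200 nM
- compound 2 `CC1CCCCN1CC(=O)N1N=C(c2cc3ccccc3oc2=O)CC1c1ccccc1`: in this assay compound 2 gives 36300 nM
- compound 3 `CC(C)(C)OC(=O)N1CCN(CC(=O)N2N=C(c3cc4ccccc4oc3=O)CC2c2ccccc2)CC1`: in this assay compound 3 gives 36400 nM

Compound 3 has the highest number of the three, but its gap to compound 2 is within the scatter, so the two cannot be ordered; only compound 1 stands apart, with a number lower than that of compound 3 beyond the scatter. Within the data shown here, the one step between neighbours, a 2.8-fold higher number from compound 1 to compound 2 (0.44 log units; beyond the scatter), concerns the group on the carbonyl carbon and not the ring nitrogen.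

Compound 4 `CN1CCN(CC(=O)N2N=C(c3cc4ccccc4oc3=O)CC2c2ccccc2)CC1` differs from compound 3 as follows: methyl in place of tert-butoxycarbonyl on an amine nitrogen in a ring. Among the measured compounds shown here, no measured pair exchanges a group on that nitrogen, so no step bears directly on this change. Compounds 2 and 3, which share the acetamide linked to a cyclic amine, sit within the scatter of each other despite different rings; a small change on that ring is therefore expected to give no step beyond the scatter. For compound 4 the expected step is a 1.2-fold lower number from compound 3 to compound 4 (0.08 log units; within the scatter). In this assay compound 4 is estimated at 30000 nM, with a range from 10000 nM to 90000 nM.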

Compound 4, half-maximal inhibitory concentration: 25800 nM
Compound 4: the middle estimate sits 1.2-fold (0.07 log units) above what was measured, within the range that was stated.
By their numbers in this assay, from the lowest: compounds 1, 4, 2 and 3 (each within the scatter of the next, the first and the last beyond it).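

In this assay, methyl in place of tert-butoxycarbonyl on the amine nitrogen in a ring gives a 1.4-fold lower number from compound 3 to compound 4 (0.15 log units; within the scatter), so this nitrogen carries either group, with 1 or 7 heavy atoms, without a step beyond the scatter. The change of ring gives a 1.4-fold lower number from compound 2 to compound 4 (0.15 log units; within the scatter), also unresolved, and the exchange for 4-methylphenyl gives a 2.0-fold higher number from compound 1 to compound 4 (0.29 log units; within the scatter), which leaves compound 4 within the scatter of compound 1, whereas a 2.8-fold higher number from compound 1 to compound 2 (0.44 log units; beyond the scatter) lies beyond it. No measurement at hand accounts for these numbers.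

Open, on these data alone, is whether an unsubstituted amine nitrogen, or a longer chain ending in a carboxylic acid on that nitrogen, would give a step beyond the scatter. Also open, as far as these compounds go, is whether a benzyl group there would separate from compound 3.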